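From 2-Chlorophenyl to 4-Methoxyphenyl on the Amide Nitrogen

The source may report more compounds than this note shows. Statements on the series, on what has been measured and on what is new or still open speak of the compounds shown alone.

In a functional assay on HeLa cells (Homo sapiens) for inhibition, read by MTT assay, with a stated time of 48 h (a higher number here means a weaker inhibitor, a lower number a stronger inhibitor), compound 1 (`O=C(/C=C/c1coc2cc(O)ccc2c1=O)NCc1ccccc1`) is recorded only as a limit of the assay (> 100000 nM). Within the data shown here, compound 2 (`COc1ccc2c(=O)c(/C=C/C(=O)Nc3ccccc3Cl)coc2c1`) gives the only actual number in the set (22400 nM), so it can be placed on no scale of measured values. Compound 3 (`COc1ccc(NC(=O)/C=C/c2coc3cc(OC)ccc3c2=O)cc1`) keeps the core of compound 2 but carries 4-methoxyphenyl in place of 2-chlorophenyl on an amide-type nitrogen. Among the measured compounds shown here, no measured step is available as a guide, so no change beyond the usual scatter is expected (a 1.3-fold higher number from compound 2 to compound 3 (0.13 log units; within the scatter)). Compound 3 is estimated at 30000 nM (expected range 10000 nM to 90000 nM).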

Compound 3, half-maximal inhibitory concentration: 13000 nM
Compound 3: the middle estimate sits 2.3-fold (0.36 log units) above what was measured; the range from low to high includes it.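

In this assay, among these compounds, the exchange of 2-chlorophenyl for 4-methoxyphenyl on the amide-type nitrogen gives the only readable step at this position, a 1.7-fold lower number from compound 2 to compound 3 (0.24 log units; within the scatter), so these two groups cannot be told apart here. Unlike the earlier compounds, this pair shows that the position can take a different substituted phenyl, with an added hydrogen-bond acceptor, without a change beyond the usual scatter. Compound 1 remains a limit of the assay, not a number: the limit of > 100000 nM in this assay, at which 1 of the 3 values shown sits.

As far as these compounds go, whether an amine, a carboxylic acid or a longer chain on this nitrogen would move the number beyond the scatter stays open. So does the effect of a different group on the shared core.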